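A few compounds are considered here, and "the series" means these few. Any claim that something is new, unique, unknown or untested is made for them only; others in the source may bear on it.

Measured so far in a physicochemical assay for acid dissociation:
compound 1 `COc1ccc(F)cc1CNCCCNc1ccnc2cc(C3CCCCC3)ccc12` gives 9.47
compound 2 `COc1cccc(CNCCCNc2ccnc3cc(Oc4cccc(N(C)C)c4)ccc23)c1O` gives 9.28

Compound 1 stands at the higher of the two numbers, and its nearest neighbour is compound 2, whose number lies within the scatter of it, so no order between the two can be read. Among the measured compounds shown here, the two measured compounds differ in more than one place, and no single step between them is available to lean on.

Compound 3 `COc1ccc(F)cc1CNCCCNc1ccnc2cc(-c3ccccc3)ccc12` is not yet measured in this assay. Against compound 1 the change is phenyl in place of cyclohexyl on an aromatic carbon. The change sits on an aromatic carbon of the core, meta to a fused ring and para to a fused ring, and nothing in the measured pair tells what such an exchange does to acid dissociation here. The expected step is a number 0.07 log units lower from compound 1 to compound 3 (within the scatter), that is none beyond the scatter, on the ground that the exchanged groups carry no donors, acceptors or charge. For compound 3 the estimate is 9.4, with a range from 9 to 9.8.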

Compound 3, acid dissociation constant: 9.47
Estimate against measurement, compound 3: 0.07 log units below; the range from low to high includes it.
By their numbers in this assay, from the lowest: compounds 2, 1 and 3 (each within the scatter of the next).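

In this assay, among the compounds shown here, the exchange of phenyl in place of cyclohexyl on an aromatic carbon gives no change at the digits printed from compound 1 to compound 3 (within the scatter) and provides the only single-place comparison so far, which the earlier pair, differing in more than one place, could not supply. At this position, meta to a fused ring and para to a fused ring, a six-membered non-aromatic ring of carbon only and a six-membered aromatic ring of carbon only therefore give values that cannot be told apart, with both groups carrying no hydrogen-bond donors, no hydrogen-bond acceptors and no net charge. No supporting measurement bears on why the read-out stays within the scatter for this exchange.

For the compounds shown here, this single step covers only two carbon-only rings, so what a carboxylic acid or a primary amine on the same aromatic carbon would do to the read-out remains open. Also open, from the compounds shown here alone, is whether phenyl in place of cyclohexyl would give the same outcome with a longer chain in the side arm shared by compound 1 and compound 3.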